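The source may hold more compounds than are shown below. What is called first, only, known or untested is meant among the compounds shown, and "the series" means these compounds.

Compound 1, with the structure `CCCn1c(=O)[nH]c2nc(-c3ccc(S(=O)(=O)N4CCN(Cc5ccc(Br)cc5)CC4)cc3)[nH]c2c1=O`, is the starting point of this account. In an assay on CHO cells for displacement of a labelled ligand from adenosine receptor A3 (Homo sapiens), read by scintillation counting, with a stated time of 45 min, tested at 1 uM, in the presence of a further agent that is not named here (on this read-out lower numbers stand for less inhibition and higher numbers for more inhibition at the one concentration tested (going by the name of the read-out)), compound 1 gives 28%. Among the three measured compounds it sits at the low end of the numbers, but only by margins that the measured steps place within the scatter. Compound 2, `CCCn1c(=O)[nH]c2nc(-c3ccc(S(=O)(=O)N4CCN(c5ccc(I)cc5)CC4)cc3)[nH]c2c1=O`, gives 36%, and compound 3, `CCCn1c(=O)[nH]c2nc(-c3ccc(S(=O)(=O)N4CCN(c5ccc(F)cc5)CC4)cc3)[nH]c2c1=O`, gives 38%. The step of a number 8 percentage points higher from compound 1 to compound 2 (within the scatter) and the step of a number 10 percentage points higher from compound 1 to compound 3 (within the scatter) each replace the whole group on the amine nitrogen in the ring, while a number 2 percentage points higher from compound 2 to compound 3 (within the scatter) swaps one halogen for another on the aromatic carbon; none of these rises above the scatter.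

Compound 4, `CCCn1c(=O)[nH]c2nc(-c3ccc(S(=O)(=O)N4CCN(Cc5cccc(Br)c5)CC4)cc3)[nH]c2c1=O`, has not been measured. It differs from compound 1 by 3-bromophenyl in place of 4-bromophenyl on a saturated chain carbon bound to an amine nitrogen in a ring. Going by the values given here, no measured step moves a halogen around the same ring while keeping the benzyl link, so nothing bears on this change directly. Among the compounds with values here, the only guidance is that every measured change in this region of the molecule stayed within the scatter. Compound 4 is therefore expected to show a step of a number 2 percentage points higher from compound 1 to compound 4 (within the scatter), that is, no shift beyond the scatter. The estimate for compound 4 is 30%, with a range from 15% to 45%.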

Compound 4, a percentage reported as inhibition, at one concentration (the size of the read-out at that concentration, not a potency): 23%
Compound 4: the middle estimate sits 7 percentage points above what was measured; measured number inside the range.
By their numbers in this assay, from the lowest: compounds 4, 1, 2 and 3 (each within the scatter of the next, the first and the last beyond it).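

In this assay, the change from 4-bromobenzyl to 3-bromobenzyl gives a number 5 percentage points lower from compound 1 to compound 4 (within the scatter), so this first direct test of where the bromine sits on the benzyl group, with the same atoms joined differently, yields no change that can be told from the scatter. Going by these compounds alone, two wider changes on the amine nitrogen in the ring do go further, with a number 15 percentage points lower from compound 3 to compound 4 (beyond the scatter) and a number 13 percentage points lower from compound 2 to compound 4 (beyond the scatter), and these are the first steps in this set beyond the scatter, although each replaces a halogenated phenyl group with 3-bromobenzyl and so cannot be assigned to the link, the halogen or its place alone. Nothing at hand gives a reason for the size of any of these steps.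

Still open, on these data alone, is whether an unsubstituted benzyl group, or a chloro, methoxy or carboxylic acid group in place of the bromine, would move the number beyond the scatter from that of compound 1. Also open, as far as these compounds go, is what a longer chain in place of the benzyl link would do, and whether these single-concentration numbers would hold their order across a full concentration series.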